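The source may report more compounds than this note shows. Statements on the series, on what has been measured and on what is new or still open speak of the compounds shown alone.

Compound 1 `COC1CN(C(=O)/C=C/c2ccncc2-c2ccc3ccccc3c2)C1`: > 10000 nM
Compound 2 `CNC(=O)/C=C/c1ccncc1-c1ccc2[nH]ccc2c1`: > 10000 nM

Of the compounds shown here, two have been measured in a functional assay on KB cells (Homo sapiens) for inhibition, read by sulforhodamine B assay, with a stated time of 72 h; a higher number here means a weaker inhibitor of growth, a lower number a stronger inhibitor of growth. Compound 1 gives only a limit there, > 10000 nM, which is not a number but the edge of what the assay can report. Compound 2 likewise gives only a limit, > 10000 nM. So compound 1 sits at the limit of > 10000 nM in this assay, at which 2 of the 2 values shown sit, with nothing to separate it from compound 2.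

Compound 3 `CN1CCN(C(=O)/C=C/c2ccncc2-c2ccc3ccccc3c2)CC1` differs from compound 1 in one place: 4-methylpiperazin-1-yl in place of 3-methoxyazetidin-1-yl on a carbonyl carbon. Among the compounds with values here, no step between measured compounds is known here, so there is no measured guide to how this change acts. Both known values rest at the same limit, and the expectation is that the step is none beyond the usual scatter, with compound 3 again most likely reported only as a limit. The estimated step is a step that the limit leaves unreadable from compound 1 to compound 3, and compound 3 is expected to give 15000 nM, between 3000 nM and 60000 nM.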

Compound 3, concentration for 50% growth inhibition: > 10000 nM
Compound 3 ended at the assay's limit; the forecaster's own chance of this, stated with the estimate: 75%; the middle value lies beyond the limit too.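

No step can be read between compound 1 and compound 3, since both results are limits and not numbers: the limit of > 10000 nM in this assay, at which 3 of the 3 values shown sit. The compounds shown leave open how strongly each inhibits growth in this assay and whether 4-methylpiperazin-1-yl in place of 3-methoxyazetidin-1-yl changes that at all.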